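The compounds below may be only part of what the source reports. "The series", "measured", "known", "first", "only" and "open" are said of these compounds alone.

Going by the values given here, compound 3 `Cc1cc(NC(=O)OC(C)(C)C(F)(F)F)nn1Cc1cc(Cl)ccc1OCC(C)C` carries the only number in this set of values. In a physicochemical assay for lipophilicity, at pH 7.4 (on this read-out lower numbers stand for lower lipophilicity and higher numbers for higher lipophilicity), compound 3 gives 3.5. Compound 1 `Cc1cc(NC(=O)OC(C)(C)C)nn1Cc1cc(Cl)ccc1OCC(C)C` reaches only a limit of this assay, > 3.7. Compound 2 `Cc1cc(NC(=O)OC(C)C)nn1Cc1cc(Cl)ccc1OCC(C)C` likewise reaches only a limit, > 3.7. Two of the three values thus sit at the limit of > 3.7 in this assay, at which 2 of the 3 values shown sit, so a number at least 0.20 log units lower from compound 1 to compound 3 (that floor lies within the scatter) and a number at least 0.20 log units lower from compound 2 to compound 3 (that floor lies within the scatter) are readable only as floors, while a step that the two limits leave unreadable from compound 1 to compound 2. Compound 4 `Cc1cc(NC(=O)OC2CCOCC2)nn1Cc1cc(Cl)ccc1OCC(C)C` differs from compound 3 by oxan-4-yl in place of 1-methyl-1-(trifluoromethyl)ethyl on an oxygen next to a carbonyl group. Among the compounds with values here, no measured step exchanges the whole group on that oxygen for a ring, so none bears directly on this change. For compound 4 a value lower than compound 3 is nonetheless expected, the estimated step being a number 0.70 log units lower from compound 3 to compound 4 (beyond the scatter). The estimate for compound 4 is 2.8, ranging from 2.3 to 3.3.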

Compound 4, distribution coefficient: 3.4
Compound 4: middle estimate off by 0.60 log units, on the low side, outside the stated range (above it).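

In this assay, oxan-4-yl on an oxygen next to a carbonyl group brings a six-membered ring with one hetero atom to this position, yet the result against 1-methyl-1-(trifluoromethyl)ethyl is a number 0.10 log units lower from compound 3 to compound 4 (within the scatter), so these two groups cannot be told apart. Against isopropyl the result is a number at least 0.30 log units lower from compound 2 to compound 4 (that floor lies within the scatter), and against tert-butyl it is a number at least 0.30 log units lower from compound 1 to compound 4 (that floor lies within the scatter). Neither floor gives the size of its step: the limit of > 3.7 in this assay, at which 2 of the 4 values shown sit.

On these data alone, whether an amine or a carboxylic acid within the group on that oxygen would give a step beyond the scatter stays open.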